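Adding a methylsulfanyl side chain to an antinociceptive glycinamide ester

The source may hold more compounds than are shown below. What is called first, only, known or untested is meant among the compounds shown, and "the series" means these compounds.

Of the compounds shown here, three built on a shared core have been tested in a functional assay on the whole organism (Tail, strain ICR) with Mus musculus as the target, in the tail flick test, with a stated time of 90 min, at a dose of 25 umol/kg by the oral route; on this read-out higher numbers stand for a stronger effect at the one dose given and lower numbers for a weaker effect. Compound 1, with the structure `C[C@H](NC(=O)CN(c1nc(Cl)nc2[nH]cnc12)C1CC1)C(=O)OCc1ccccc1`, gives 44.2% in this assay. Compound 2, with the structure `O=C(CN(c1ncnc2c1ncn2C1CCCCO1)C1CC1)NCC(=O)OCc1ccccc1`, gives 25.9%, and compound 3, with the structure `CC[C@H](C)[C@H](NC(=O)CN(c1nc(Cl)nc2[nH]cnc12)C1CC1)C(=O)O`, gives 27.4%. Compound 1 therefore stands highest of the three numbers: its nearest neighbour is compound 3, whose number lies lower by an amount beyond the usual scatter, and compound 2 lies further below it, again beyond the scatter.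

Compound 4, with the structure `CSCC[C@H](NC(=O)CN(c1nc(Cl)nc2[nH]cnc12)C1CC1)C(=O)OCc1ccccc1`, has not yet been measured in this assay. It differs from compound 1 in a single place: (methylsulfanyl)methyl in place of hydrogen on a saturated chain carbon, two bonds along the chain from an amide-type nitrogen and a carbonyl carbon. The new group carries one hydrogen-bond acceptor and no ring, and it sits on the saturated chain carbon that bears the ester.

Among the measured compounds shown here, no measured pair in this set shares exactly this change, so its effect can only be guessed from how far compound 1 sits above the other two. A modest downward step is expected, from compound 1 to compound 4, of a number 6.2 percentage points lower from compound 1 to compound 4 (within the scatter), a shift that may not clear the scatter. Compound 4 is therefore estimated to give 38% in this assay, within a range from 20% to 58%.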

Compound 4, a percentage reported as activity, at one dose (the size of the read-out at that dose, not a potency): 44.6%
Estimate against measurement, compound 4: 6.6 percentage points below, and the stated range covers the measured number.
By their numbers in this assay, from the lowest: compounds 2 and 3 (each within the scatter of the next); then compounds 1 and 4 (each within the scatter of the next).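

In this assay the change reads as a number 0.4 percentage points higher from compound 1 to compound 4 (within the scatter), so compound 1 and compound 4 cannot be told apart on this read-out. Among the compounds shown here, this is the first one-place comparison in the set, and it shows that the saturated chain carbon bearing the ester can carry (methylsulfanyl)methyl in place of hydrogen while the effect at this one dose stays within the usual scatter of compound 1. Nothing measured here explains why the two compounds read alike, and no outside data on this change are at hand.

Open still is whether this position would give the same read-out with a side chain lacking sulfur, such as a plain propyl chain, or with one ending in an amine or a hydroxyl group. A single dose at a single time also leaves open whether compound 1 and compound 4 would still match at other doses or times, since a read-out of this kind measures the size of the effect at that dose and not potency.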